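From Chloro to Azido: A Small Swap, Little Expected

A few compounds are considered here, and "the series" means these few. Any claim that something is new, unique, unknown or untested is made for them only; others in the source may bear on it.

Of the compounds shown here, three have been measured in a functional assay (Homo sapiens) for inhibition of Nucleic Acid, tested at 100 uM; a higher number here means more inhibition at the concentration tested (going by the name of the read-out), a lower number less inhibition. Compound 1 `[O-][n+]1ccc2c(c1)ncn2[C@H]1C[C@H](O)[C@@H](CO)O1` gives 0%. Compound 3 `CCNc1nccc2c1ncn2C1O[C@H](CO)[C@@H](O)[C@H]1O` gives 4%. Compound 2 `Clc1[nH]ccc2ncnc1-2` gives 6%, the largest of the three numbers, yet the value of compound 3 lies only a little under it and the value of compound 1 a little further under it, both within the usual scatter of repeated measurements. On these numbers, none of the three stands apart from the others; all show little inhibition.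

Compound 4 `[N-]=[N+]=Nc1[nH]ccc2ncnc1-2` has not yet been measured. It differs from compound 2 in one place: azido in place of chloro on an aromatic carbon. Since every measured compound sits close to the bottom of the scale, no step beyond the scatter is expected from this change, in either direction. Compound 4 is therefore expected to give 5%, with a likely range from -5% to 20%. This means an expected change of a number 1 percentage points lower from compound 2 to compound 4 (within the scatter), a step no larger than the scatter itself.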

Compound 4, a percentage reported as inhibition, at one concentration (the size of the read-out at that concentration, not a potency): 20%
Estimate against measurement, compound 4: 15 percentage points below; low and high end bracket the measured number.
By their numbers in this assay, from the lowest: compounds 1, 3 and 2 (each within the scatter of the next); then compound 4.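

In this assay, azido in place of chloro on an aromatic carbon gives a number 14 percentage points higher from compound 2 to compound 4 (beyond the scatter). Within the data shown here, this shows that a change at this carbon, next to the ring nitrogen of the six-membered aromatic ring, can move the read-out beyond the scatter, which the earlier compounds, all within the scatter of one another, could not show. Nothing in the data explains why this swap raises the number.

On these data alone, it remains open whether the rise is particular to azido, and a methoxy group or a nitrile on the same carbon would help to settle that. Also open, as far as these compounds go, is whether azido would outdo chloro in the same way on the core of compound 3, which differs from compound 4 in more than one place.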